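The source may hold more compounds than are shown below. What is called first, only, known or untested is meant among the compounds shown, and "the series" means these compounds.

Compound 2 `COc1ccc(-n2nc(C(=O)Nc3ccc(Oc4ccnc5cc(OCCCN6CCCCC6)c(OC)cc45)c(F)c3)c(C)cc2=O)cc1` gives 1500 nM in a functional assay on A549 cells (Homo sapiens) for inhibition, read by MTT assay, with a stated time of 72 h (on this read-out lower numbers stand for stronger inhibition and higher numbers for weaker inhibition), the higher of the two numbers recorded, and it stands apart from compound 1 `COc1cc2c(Oc3ccc(NC(=O)c4nn(-c5ccccc5)c(=O)cc4C)cc3F)ccnc2cc1OCCCN1CCCCC1`, which in this assay gives 150 nM. Among the compounds with values here, the one step joining these two, a 10-fold higher number from compound 1 to compound 2 (1.00 log units; beyond the scatter), is the only measured comparison in the set. Compound 3 `COc1cc2c(Oc3ccc(NC(=O)c4nn(-c5ccc(Cl)cc5Cl)c(=O)cc4C)cc3F)ccnc2cc1OCCCN1CCCCC1` has not yet been measured; it differs from compound 2 by 2,4-dichlorophenyl in place of 4-methoxyphenyl on an aromatic nitrogen. Within the data shown here, because a 10-fold higher number from compound 1 to compound 2 (1.00 log units; beyond the scatter) shows what the methoxy group costs, its removal in compound 3 is expected to recover part of that loss, while the two chlorines have no measured precedent here and add uncertainty in either direction. On that basis compound 3 is expected to show a 5.0-fold lower number from compound 2 to compound 3 (0.70 log units; beyond the scatter). The estimate for compound 3 in this assay is therefore 300 nM, with a plausible range from 80 nM to 1200 nM.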

Compound 3, half-maximal inhibitory concentration: 220 nM
Compound 3: middle estimate off by 1.4-fold (0.13 log units), on the high side; measured number inside the range.
By their numbers in this assay, from the lowest: compounds 1 and 3 (each within the scatter of the next); then compound 2.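

In this assay the change to 2,4-dichlorophenyl on the aromatic nitrogen gives a 6.8-fold lower number from compound 2 to compound 3 (0.83 log units; beyond the scatter) and so shows that the loss seen with 4-methoxyphenyl does not extend to every substituted phenyl at this place. Set against the plain phenyl, the same group gives a 1.5-fold higher number from compound 1 to compound 3 (0.17 log units; within the scatter) and this leaves 4-methoxyphenyl as the only one of the three groups that stands apart, since this place carries two chlorines with no change that can be told from the scatter. Nothing measured here explains this difference between the groups.

The two chlorines entered together, so the compounds shown leave open what each contributes alone. They also leave open whether a phenyl carrying a single fluorine, a trifluoromethyl group or a dimethylamino group would behave like 2,4-dichlorophenyl or like 4-methoxyphenyl.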